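The compounds below may be only part of what the source reports. "The series", "measured", "known", "first", "only" and "open" are said of these compounds alone.

Compound 3 `CCC(C(=O)NCc1cccc(Cl)c1)N1C(=O)CCC1=O` gives 78.9 mg/kg in a functional assay on the whole organism (strain Albino Swiss CD1) with Mus musculus as the target (a lower number here means that less compound is needed, a higher number that more compound is needed for the effect), which places it second highest among the three measured numbers, with compound 2 `CCC(C(=O)NCc1ccccc1Cl)N1C(=O)CCC1=O` nearest and compound 1 `CCC(C(=O)NCc1ccccc1)N1C(=O)CCC1=O` furthest. In this assay compound 1 gives 90.3 mg/kg and compound 2 gives 76.4 mg/kg. The change from compound 3 to compound 4 `CCC(C(=O)NCc1ccccc1F)N1C(=O)CCC1=O` is 2-fluorophenyl in place of 3-chlorophenyl on a saturated chain carbon bound to an amide-type nitrogen. Among the measured compounds shown here, three measured steps bear on it: a 1.2-fold lower number from compound 1 to compound 2 (0.07 log units; within the scatter), a 1.1-fold lower number from compound 1 to compound 3 (0.06 log units; within the scatter) and a 1.0-fold higher number from compound 2 to compound 3 (0.01 log units; within the scatter). None of these halogen changes on the phenyl ring shifted the number beyond the scatter, so for compound 4 no step beyond the scatter is expected, a 1.0-fold higher number from compound 3 to compound 4 (0.01 log units; within the scatter). Compound 4 is therefore estimated at 80 mg/kg, with a range from 50 mg/kg to 130 mg/kg.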

Compound 4, dose for half-maximal effect: 65.7 mg/kg
Estimate against measurement, compound 4: 1.2-fold (0.09 log units) above; the range from low to high includes it.
By their numbers in this assay, from the lowest: compounds 4, 2, 3 and 1 (each within the scatter of the next).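

Fluoro joins hydrogen and chloro on the phenyl ring, and this assay still does not separate them (a 1.2-fold lower number from compound 3 to compound 4 (0.08 log units; within the scatter); a 1.2-fold lower number from compound 2 to compound 4 (0.07 log units; within the scatter); a 1.4-fold lower number from compound 1 to compound 4 (0.14 log units; within the scatter)). Even the direct swap of hydrogen for fluoro stays within the scatter, so these four compounds cannot be told apart by this read-out. Nothing measured here offers an explanation for how close the numbers lie. Still open, going by these compounds, is whether a methoxy group, an amine or a carboxylic acid on the phenyl ring would shift the number beyond the scatter. On these data alone, a longer chain on the shared core remains equally open.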